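From a carboxyethyl amide to a hydroxyethyl amide

The source may hold more compounds than are shown below. What is called first, only, known or untested is meant among the compounds shown, and "the series" means these compounds.

Of the compounds shown here, three with a shared core have been tested in a functional assay on Caco-2 cells (Homo sapiens) for antiproliferative activity, read by MTT assay, with a stated time of 48 h; a higher number here means a weaker inhibitor, a lower number a stronger inhibitor. For compound 1 `C#CCCOC(=O)c1ccc(C(CC)(CC)c2ccc(OCCC(O)(CC)CC)c(C)c2)n1CC` the assay reports only a limit, > 50000 nM. Compound 2 `CCOC(=O)C(CC(=O)OC)NC(=O)c1ccc(C(CC)(CC)c2ccc(OCCC(O)(CC)CC)c(C)c2)n1CC` gives 3020 nM. Compound 3 `CCn1c(C(=O)NC(C)C(=O)O)ccc1C(CC)(CC)c1ccc(OCCC(O)(CC)CC)c(C)c1` gives 46500 nM, the higher of the two values measured as actual numbers.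

Compound 4 `CCn1c(C(=O)N(C)CCO)ccc1C(CC)(CC)c1ccc(OCCC(O)(CC)CC)c(C)c1` differs from compound 3 by one change ((2-hydroxyethyl)(methyl)amino in place of (1-carboxyethyl)amino on a carbonyl carbon), which puts (2-hydroxyethyl)(methyl)amino in place of (1-carboxyethyl)amino on a carbonyl carbon. The nearest measured evidence is mixed. Compound 2 also lacks the carboxy group of compound 3, and the step of a 15-fold higher number from compound 2 to compound 3 (1.19 log units; beyond the scatter) is large. Compound 1 lacks that group too and goes against this reading, since the step of an at least 1.0-fold lower number from compound 1 to compound 3 (0.03 log units; that floor lies within the scatter) has a floor within the scatter. A moderate fall in this assay is therefore expected, smaller than the gap between compound 2 and compound 3. The expected step is a 2.9-fold lower number from compound 3 to compound 4 (0.46 log units; beyond the scatter). Compound 4 is estimated at 16000 nM, within an expected range of 4000 nM to 50000 nM.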

Compound 4, half-maximal inhibitory concentration: 74 nM
Beside the measured number, compound 4's estimate is 220-fold (2.33 log units) above it, outside the stated range (below it).
By their numbers in this assay, from the lowest: compound 4; then compound 2; then compound 3. At a limit, above all of these: compound 1.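

In this assay, within the data shown here, placing (2-hydroxyethyl)(methyl)amino in place of (1-carboxyethyl)amino on the carbonyl carbon gives a 630-fold lower number from compound 3 to compound 4 (2.80 log units; beyond the scatter), which shows that this position can govern the activity far more strongly than the earlier compounds indicated. The new group also goes well past the best earlier compound, with a 41-fold lower number from compound 2 to compound 4 (1.61 log units; beyond the scatter), so the earlier low value was no floor for this series. The comparison with the ester gives an at least 670-fold lower number from compound 1 to compound 4 (2.82 log units; beyond the scatter), and that figure is only a minimum, because compound 1 stands at a limit of the assay: the limit of > 50000 nM in this assay, at which 1 of the 4 values shown sits.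

Going by these compounds, it remains open whether the gain follows the hydroxyl or the methyl on the amide nitrogen, which a 2-hydroxyethyl amide keeping the amide hydrogen or a dimethylamino group could separate. On these data alone, whether a longer chain such as 3-hydroxypropyl, or an amine at the chain end, would hold this activity also stays open.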